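A few compounds are considered here, and "the series" means these few. Any claim that something is new, unique, unknown or untested is made for them only; others in the source may bear on it.

Measured so far:
- compound 1 `CCCCCCCC/C=C\CCCCCCCC(=O)OC[C@@H](COCC)OP(=O)(O)OC[C@H](N)C(=O)O`: in an assay on HEK293 cells for agonist activity at putative P2Y purinoceptor 10 (Mus musculus), with a stated time of 1 h (a higher number here means a larger maximal response, a lower number a smaller maximal response), compound 1 gives "not active" (no number reported)
- compound 2 `CCCCCCCCCCCOc1ccccc1CCC(=O)O[C@H]1CCOC[C@@H]1OP(=O)(O)OC[C@H](N)C(=O)O`: compound 2 gives 11.1%
- compound 3 `CCCCCCCCCCCOc1ccccc1CCC(=O)O[C@H]1COCC[C@H]1OP(=O)(O)OC[C@H](N)C(=O)O`: compound 3 gives 8.6%

Compound 3 holds the lower of the two reported numbers; its nearest neighbour is compound 2, whose value lies higher by an amount within the usual scatter, so no order between the two can be read. Compound 1 yields no number at all.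

Compound 4 `CCCCCCCCCCCOc1ccccc1CCC(=O)O[C@@H]1COCC[C@H]1OP(=O)(O)OC[C@H](N)C(=O)O` is the next entry. It differs from compound 3 as follows: the two compounds have the same atoms and bonds; at least one stereo element is drawn with a configuration in one of them and without one in the other: 1 of 4 stereo elements differ; a stereocentre at a saturated ring carbon is drawn S in compound 3 and R in compound 4. Going by the values given here, no step between measured compounds is available as a guide. Given that both reported values sit close together and low, a change in configuration at one ring stereocentre is expected to give no step beyond the scatter. For compound 4 the estimate in this assay is 10%, with a range of 2% to 25%. The expected step is a number 1.4 percentage points higher from compound 3 to compound 4 (within the scatter).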

Compound 4, largest response reached (Emax), in percent of the reference or control that the assay uses: 11.4%
Beside the measured number, compound 4's estimate is 1.4 percentage points below it; measured number inside the range.
By their numbers in this assay, from the lowest: compounds 3, 2 and 4 (each within the scatter of the next).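

In this assay, going by these compounds alone, the first step between measured compounds comes from the stereocentre at a saturated ring carbon, drawn S in compound 3 and R in compound 4: a number 2.8 percentage points higher from compound 3 to compound 4 (within the scatter). At this low response level, this configuration does not separate the two compounds. One limit applies to this reading: the fact that one of compounds 3 and 4 is drawn with a defined configuration and the other without, at the place where they differ.

Open, going by these compounds, is whether configuration at this position would matter in a compound with a larger response in this assay. Also open, on these data alone, is how an amide in place of the ester on the shared core would behave.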